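A few compounds are considered here, and "the series" means these few. Any claim that something is new, unique, unknown or untested is made for them only; others in the source may bear on it.

In a toxicity assay on HepG2 cells (Homo sapiens) for inhibition (on this read-out lower numbers stand for stronger inhibition and higher numbers for weaker inhibition), compound 1 (`CCCCNc1nc(SCCCC)nc2ccc(-c3cccc(C(=O)O)c3)cc12`) gives only a limit of the method, > 37 ug/mL. Compound 2 (`CCCCSc1nc(SCCCC)c2cc(N)ccc2n1`) also stops at a limit in this assay, > 37 ug/mL. Both values therefore sit at the limit of > 37 ug/mL in this assay, at which 2 of the 2 values shown sit, so compound 2 stands where every measured value stands, with no number beyond the limit. Compound 3 (`CCCCSc1nc(SCCCC)c2cc(NS(=O)(=O)CC)ccc2n1`) carries ethylsulfonyl in place of hydrogen on a nitrogen on an aromatic ring. For the measured compounds named here, no measured step guides this change, and the expected step from compound 2 to compound 3 in this assay is a step that the limit leaves unreadable from compound 2 to compound 3, within the usual scatter. For compound 3 the estimate is 40 ug/mL, expected between 15 ug/mL and 100 ug/mL.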

Compound 3, half-maximal inhibitory concentration: > 37 ug/mL
Compound 3 was reported as a limit; the forecaster's own chance of this, stated with the estimate: 80%; the middle value is on the limit's open side.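

For the compounds shown here, no step from compound 2 to compound 3 can be read, since both values are limits and not numbers: the limit of > 37 ug/mL in this assay, at which 3 of the 3 values shown sit. The compounds shown leave open how strongly any of them inhibits in this assay, and whether ethylsulfonyl on that nitrogen changes it.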